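Sulfonyl tetrahydronaphthalene series: amide in place of cyclic amidine

A few compounds are considered here, and "the series" means these few. Any claim that something is new, unique, unknown or untested is made for them only; others in the source may bear on it.

Measured so far:
compound 1 `CNCC1CCCc2cc(S(=O)(=O)c3ccccc3)ccc21`: 0.316 nM
compound 2 `CNC[C@@H]1CCCc2cc(S(=O)(=O)c3cc[nH]c3)ccc21`: 0.159 nM
compound 3 `O=C1CN=C(NC[C@@H]2CCCc3cc(S(=O)(=O)c4cccc(F)c4)ccc32)N1`: 0.1 nM

In an assay on isolated protein for displacement of a labelled ligand from 5-hydroxytryptamine receptor 6 (Homo sapiens) (a higher number here means a weaker inhibitor, a lower number a stronger inhibitor), compound 3 gives the lowest of the three numbers; compound 2 lies within the scatter of it, while compound 1 stands beyond the scatter at a higher number. Compound 4 `CC(=O)N(C)C[C@@H]1CCCc2cc(S(=O)(=O)c3cccc(F)c3)ccc21` differs from compound 3 in one place: a group of 5 heavy atoms (3 carbon, 1 nitrogen, 1 oxygen; no ring) in place of a group of 7 heavy atoms (3 carbon, 3 nitrogen, 1 oxygen; one five-membered non-aromatic ring with 2 hetero atoms), on a saturated chain carbon bound to a saturated ring carbon. The leaving group brings 2 hydrogen-bond donors, the entering group none. For the measured compounds named here, no measured pair in the set shows a change of this kind, so its size cannot be read from the data. The expected step of a 500-fold higher number from compound 3 to compound 4 (2.70 log units; beyond the scatter) is toward a higher number, well beyond the scatter. Compound 4 is estimated at 50 nM, with a range from 5 nM to 500 nM.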

Compound 4, inhibition constant: 1.59 nM
Compound 4: middle estimate off by 31-fold (1.50 log units), on the high side, and the stated range ends above it.
By their numbers in this assay, from the lowest: compounds 3, 2 and 1 (each within the scatter of the next, the first and the last beyond it); then compound 4.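

In this assay, the saturated chain carbon bound to a saturated ring carbon proves sensitive to its substituent: acetyl(methyl)amino in place of the cyclic amidine gives a 16-fold higher number from compound 3 to compound 4 (1.20 log units; beyond the scatter). Even without hydrogen-bond donors in this group, compound 4 still gives 1.59 nM. Nothing shown accounts for the size of this step.

The change removes the ring and the donors together, so their separate contributions remain unresolved. An acetylamino group that keeps the amide hydrogen, or an open-chain urea, on the core of compound 4 would separate them.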